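Bromo for methyl on a shared urea core

The source may report more compounds than this note shows. Statements on the series, on what has been measured and on what is new or still open speak of the compounds shown alone.

Of the compounds shown here, three built on one urea core have been measured in an ADME assay on the whole organism with Oryza sativa as the target, tested at 1 uM; a lower number here means a stronger effect, a higher number a weaker effect of the compound at the concentration tested. Compound 1 `Cc1ccc(NC(=O)N[C@H](C)c2ccccc2)cc1` gives 98%, and compound 2 `Cc1ccc(NC(=O)N[C@@H](C)c2ccccc2)cc1` gives 99%. These two have the same atoms and bonds and differ only in the configuration drawn at one saturated chain carbon; the step of a number 1 percentage points higher from compound 1 to compound 2 (within the scatter) is within the scatter, as fits (the fact that compounds 1 and 2 differ only in the configuration as drawn). Compound 3 `C[C@@H](NC(=O)Nc1cccc(Cl)c1)c1ccccc1` gives 91%. All three numbers lie close together, and compound 2 stands no further from either of the others than repeated measurements of this kind usually do.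

Compound 4 `C[C@H](NC(=O)Nc1ccc(Br)cc1)c1ccccc1` has not yet been measured. Against compound 2 the change is bromo in place of methyl on an aromatic carbon. For the measured compounds named here, the only measured step concerns configuration alone and says nothing about exchanging one substituent for another, so no step beyond the scatter is expected in this assay; the expected step is a number 5 percentage points lower from compound 2 to compound 4 (within the scatter). Compound 4 is therefore estimated at 94%, with a range from 84% to 100%.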

Compound 4, a percentage reported as activity, at one concentration (the size of the read-out at that concentration, not a potency): 97%
Compound 4: the middle estimate sits 3 percentage points below what was measured, and the stated range covers the measured number.
By their numbers in this assay, from the lowest: compounds 3, 4, 1 and 2 (each within the scatter of the next).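

In this assay, bromo in place of methyl on an aromatic carbon, para to a large group, gives a number 2 percentage points lower from compound 2 to compound 4 (within the scatter). The earlier step changed only configuration, whereas this one shows that exchanging one substituent for another at this position can also stay within the scatter. Nothing available here accounts for this result.

Still open, going by these compounds, is whether a different kind of group at this position, such as an amine or a carboxylic acid, would give a step beyond the scatter.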